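Nitro for methyl on the aryl ring: what to expect

This account rests on a few compounds, and the source may have more. Where it says the series, first, only, none or still open, it means among the compounds named here.

The series shares one core, seen in compound 1 `Cn1nnnc1SCC(=O)N/N=c1/scc(-c2ccc(F)cc2)n1-c1ccccc1`, for which a functional assay on C6 cells (Rattus norvegicus) for cytotoxicity, read by MTT assay, with a stated time of 24 h (a higher number here means a weaker inhibitor, a lower number a stronger inhibitor), reports "not determined" (no result reported). Compound 2 `Cc1ccc(-c2cs/c(=N/NC(=O)CSc3nnnn3-c3ccccc3)n2-c2ccccc2)cc1` gives 14.7 ug/mL in this assay, and compound 3 `Cc1ccc(-c2cs/c(=N/NC(=O)CSc3nnnn3C)n2-c2ccccc2)cc1` gives 36.3 ug/mL. Among the measured compounds shown here, the only step with numbers on both sides, a 2.5-fold higher number from compound 2 to compound 3 (0.39 log units; beyond the scatter), is modest, and it leaves compound 3 with the higher of the two numbers, standing apart from compound 2 beyond the scatter.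

Compound 4 `Cn1nnnc1SCC(=O)N/N=c1/scc(-c2ccc([N+](=O)[O-])cc2)n1-c1ccccc1` differs from compound 3 by nitro in place of methyl on an aromatic carbon. For the measured compounds named here, no measured pair bears on this change: the step from compound 2 to compound 3 concerns the group on the aromatic nitrogen, not the group on the carbon ring, and compound 1, which carries a different group at that place, has no result. With nothing to lean on, a step no larger than the scatter is expected, in no particular direction, so a 1.1-fold lower number from compound 3 to compound 4 (0.05 log units; within the scatter) is the estimated step. Compound 4 is therefore expected to give about 32 ug/mL in this assay, between 12 ug/mL and 85 ug/mL.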

Compound 4, half-maximal inhibitory concentration: > 200 ug/mL
Compound 4 ended at the assay's limit (the forecaster's own chance of this, stated with the estimate: 10%); at least 6.2-fold (0.79 log units) between middle value and limit.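

The group on the carbon ring, which the earlier measured pair left untouched, proves to matter in this assay: the change from 4-methylphenyl to 4-nitrophenyl gives an at least 5.5-fold higher number from compound 3 to compound 4 (0.74 log units; beyond the scatter). This gives the series its first reading at this position, alongside the change on the aromatic nitrogen, which gave a 2.5-fold higher number from compound 2 to compound 3 (0.39 log units; beyond the scatter). The size of the new step has no upper bound, since what compound 4 gives is a limit of the assay and not a number: the limit of > 200 ug/mL in this assay, at which 1 of the 4 values shown sits.

From the compounds shown here alone, with only methyl and nitro compared at this position, it remains open whether an amine or a methoxy group there would stay close to compound 3 or move as nitro does. Going by these compounds, it is also open whether nitro would have the same outcome with phenyl rather than methyl on the aromatic nitrogen, as in compound 2.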